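The source may hold more compounds than are shown below. What is called first, only, known or untested is meant among the compounds shown, and "the series" means these compounds.

Compound 2 `COc1ccc(/C=C\C(=O)O)c(OCc2cn(-c3ccc(NC(=O)c4ccccc4)cc3)nn2)c1CC=C(C)C` belongs to a small set built on a shared core. Going by the values given here, in a functional assay on T47D cells (Homo sapiens) for cytotoxicity, read by MTT assay, with a stated time of 24 h (a higher number here means a weaker inhibitor, a lower number a stronger inhibitor), compound 2 gives 23300 nM, which is the highest of the two numbers known so far. Its nearest neighbour is compound 1 `COc1ccc(/C=C\C(=O)O)c(OCc2cn(-c3ccc(NC(C)=O)cc3)nn2)c1CC=C(C)C`, which in this assay gives 17400 nM; the step of a 1.3-fold higher number from compound 1 to compound 2 (0.13 log units; within the scatter) is phenyl in place of methyl on a carbonyl carbon, and it lies within the scatter. A third member, compound 3 `COc1ccc(/C=C\C(=O)O)c(OCc2cn(-c3ccccc3I)nn2)c1CC=C(C)C`, has in this assay only the entry "not determined" (no result reported), so it contributes nothing to the comparison.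

The next member, compound 4 `COc1ccc(/C=C\C(=O)O)c(OCc2cn(-c3ccc(C#N)cc3)nn2)c1CC=C(C)C`, differs from compound 2 by cyano in place of benzamido on an aromatic carbon, para to a large group. Among the compounds with values here, only one measured step exists, that from compound 1 to compound 2, and it shows that exchanging the group on the carbonyl carbon left the number unchanged beyond the scatter. That step does not cover removal of the whole benzamido in favour of cyano, so the expectation rests on the two numbers alone. With no change resolved between compound 1 and compound 2, compound 4 is expected to sit near them, and the expected step of a 1.2-fold lower number from compound 2 to compound 4 (0.07 log units; within the scatter) is estimated to stay within the scatter. Compound 4 is therefore expected to give about 20000 nM in this assay, with a range from 7000 nM to 55000 nM.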

Compound 4, half-maximal inhibitory concentration: 10200 nM
The estimate for compound 4 lay 2.0-fold (0.29 log units) above the measured number, within the range that was stated.
By their numbers in this assay, from the lowest: compounds 4, 1 and 2 (each within the scatter of the next, the first and the last beyond it).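

In this assay, going by these compounds alone, the earlier step had changed only the group on the carbonyl carbon, whereas replacing the whole benzamido on the aromatic carbon, para to a large group, gives the first step in the set that is resolved beyond the scatter, though a modest one (a 2.3-fold lower number from compound 2 to compound 4 (0.36 log units; beyond the scatter)). The corresponding exchange of acetamido for cyano at the same place stays within the scatter (a 1.7-fold lower number from compound 1 to compound 4 (0.23 log units; within the scatter)), so cyano is set apart from benzamido but not from acetamido, and no ordering of the three groups can be drawn beyond that single resolved difference. No measurement accompanying these compounds offers an explanation for the difference between these two exchanges.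

The compounds shown leave open how an amine, a methoxy group or a chlorine atom on this aromatic carbon would compare with cyano, and so whether the number can move further in either direction from this position. They also leave open whether the step from benzamido to cyano would hold if the prenyl chain on the shared core were replaced by a methyl group.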